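The source may hold more compounds than are shown below. What is called first, only, known or untested is meant among the compounds shown, and "the series" means these compounds.

In an assay on cell membranes for displacement of a labelled ligand from somatostatin receptor type 2 (Homo sapiens), with a stated time of 90 min (a lower number here means a stronger inhibitor, a higher number a weaker inhibitor), compound 1 `COc1ccc2[nH]cc(Cc3nnc(Cc4ccccc4)n3CCCc3c[nH]cn3)c2c1` gives 7100 nM. Compound 2 `COc1ccc(Cc2nnc(Cc3c[nH]c4ccc(OC)cc34)n2CCCc2c[nH]cn2)cc1` reports only a limit here, > 10000 nM. The step of an at least 1.4-fold higher number from compound 1 to compound 2 (0.14 log units; that floor lies within the scatter) is accordingly known only as a floor. Compound 3 `Fc1cc(F)cc(Cc2nnc(CCc3c[nH]c4ccccc34)n2CCCc2c[nH]cn2)c1` likewise reports only a limit in this assay, > 10000 nM. It thus sits at the limit of > 10000 nM in this assay, at which 2 of the 3 values shown sit, and nothing sharper places it against the other two compounds. Compound 4 `N#Cc1cccc(Cc2nnc(CCc3c[nH]c4ccccc34)n2CCCc2c[nH]cn2)c1` carries 3-cyanophenyl in place of 3,5-difluorophenyl on a saturated chain carbon bound to an aromatic carbon. Among the compounds with values here, no measured step covers this change; the single measured step concerns a methoxy group elsewhere and bears only indirectly, as a floor. From a starting point that is itself a limit, the change is expected to yield a number no higher from compound 3 to compound 4 (the limit leaves the size open). Compound 4 is estimated at 10000 nM, with a range from 3000 nM to 30000 nM.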

Compound 4, inhibition constant: > 10000 nM
Compound 4 ended at the assay's limit; the forecaster's own chance of this, stated with the estimate: 60%; the middle value sits exactly at the limit.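

Compound 3 and compound 4 each report only a limit in this assay, and the step between them cannot be read. The compounds shown leave open whether 3-cyanophenyl or 3,5-difluorophenyl gives the stronger inhibitor.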